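Formyl for (methoxymethoxy)methyl in a quinolinone cytotoxicity series

The source may report more compounds than this note shows. Statements on the series, on what has been measured and on what is new or still open speak of the compounds shown alone.

Measured so far:
compound 1 `C=CCn1c(-c2cc(OC)c(OC)cc2COCOC)cc2ccccc2c1=O` — 88100 nM
compound 2 `COCOCc1cc(OC)c(OC)cc1-c1cc2ccccc2c(=O)[nH]1` — 85100 nM

In a functional assay on A549 cells (Homo sapiens) for cytotoxicity, read by MTT assay, with a stated time of 48 h (a lower number here means a stronger inhibitor, a higher number a weaker inhibitor), compound 1 gives 88100 nM, the highest of the two numbers in hand, with compound 2 nearest at 85100 nM; the step of a 1.0-fold lower number from compound 1 to compound 2 (0.02 log units; within the scatter) lies within the scatter, so the two compounds cannot be told apart on these numbers.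

Compound 3 `C=CCn1c(-c2cc(OC)c(OC)cc2C=O)cc2ccccc2c1=O` is not yet measured. It differs from compound 1 by formyl in place of (methoxymethoxy)methyl on an aromatic carbon. Going by the values given here, the only measured step, that from compound 1 to compound 2, concerns a different part of the molecule, the group on the aromatic nitrogen, and so gives no direct guide to an exchange on the aromatic carbon. Nothing in the series shows what replacing (methoxymethoxy)methyl by formyl does in this assay. The expectation is therefore anchored on compound 1 alone, with no step beyond the scatter expected in either direction, but with a wide range to reflect the missing evidence. For compound 3 the estimated value is 70000 nM, between 15000 nM and 250000 nM, which corresponds to an expected step of a 1.3-fold lower number from compound 1 to compound 3 (0.10 log units; within the scatter).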

Compound 3, half-maximal inhibitory concentration: 76300 nM
Beside the measured number, compound 3's estimate is 1.1-fold (0.04 log units) below it; measured number inside the range.
By their numbers in this assay, from the lowest: compounds 3, 2 and 1 (each within the scatter of the next).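

In this assay, the aromatic carbon ortho to a large group now has its first reading, and the exchange of (methoxymethoxy)methyl for formyl gives a 1.2-fold lower number from compound 1 to compound 3 (0.06 log units; within the scatter). The earlier pair spoke only to the group on the aromatic nitrogen, whereas this pair shows that a group of 5 heavy atoms with 2 hydrogen-bond acceptors and a group of 2 heavy atoms with 1 hydrogen-bond acceptor cannot be told apart at this carbon on the core of compound 1. No other measurement here bears on why these two compounds read alike.

With only these two groups at this position, the reading says nothing about whether a group of a different kind, such as an amine, a carboxylic acid or a longer alkyl chain, would move the number beyond the scatter. Also open, as far as these compounds go, is whether formyl at this carbon would read the same with the hydrogen of compound 2 on the aromatic nitrogen in place of allyl.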